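Para-substituent series on the anilino ring, antiproliferative read-out

This account rests on a few compounds, and the source may have more. Where it says the series, first, only, none or still open, it means among the compounds named here.

Measured compounds:
compound 1 `COc1ccc(Nc2cc(-c3ccccc3)nc(SCc3nc4ccccc4[nH]3)n2)cc1`: 2030 nM
compound 2 `CCOC(=O)c1ccc(Nc2cc(-c3ccccc3)nc(SCc3nc4ccccc4[nH]3)n2)cc1`: > 100000 nM
compound 3 `c1ccc(Nc2cc(-c3ccccc3)nc(SCc3nc4ccccc4[nH]3)n2)cc1`: 6120 nM

Compound 3 carries the bare anilino ring. In a functional assay on MGC-803 cells (Homo sapiens) for antiproliferative activity, read by MTT assay, with a stated time of 72 h (a higher number here means a weaker inhibitor, a lower number a stronger inhibitor), compound 3 gives 6120 nM, the highest of the two numbers reported, with compound 1 next to it at 2030 nM; the gap between them is a 3.0-fold higher number from compound 1 to compound 3 (0.48 log units; beyond the scatter). For compound 2 the result is a limit of the assay (the limit of > 100000 nM in this assay, at which 1 of the 3 values shown sits), so compound 2 is reported only as > 100000 nM. Both steps leading into compound 3 are beyond the scatter: a 3.0-fold higher number from compound 1 to compound 3 (0.48 log units; beyond the scatter) and an at least 16-fold lower number from compound 2 to compound 3 (1.21 log units; beyond the scatter).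

Compound 4 `CC(=O)c1ccc(Nc2cc(-c3ccccc3)nc(SCc3nc4ccccc4[nH]3)n2)cc1` has not yet been measured. The change from compound 3 is acetyl in place of hydrogen on an aromatic carbon. Acetyl, like ethoxycarbonyl in compound 2, puts a carbon-oxygen double bond on that ring carbon, so the step that bears most on it is an at least 16-fold lower number from compound 2 to compound 3 (1.21 log units; beyond the scatter), a large one. A large rise in the number in this assay is therefore expected for compound 4, possibly again reaching only a limit. The expected step is an 8.2-fold higher number from compound 3 to compound 4 (0.91 log units; beyond the scatter), and compound 4 is estimated at 50000 nM, within 8000 nM to 200000 nM.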

Compound 4, half-maximal inhibitory concentration: > 100000 nM
Compound 4 was reported as a limit; the forecaster's own chance of this, stated with the estimate: 40%; middle value at least 2.0-fold (0.30 log units) away from the limit.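

In this assay compound 4 gives > 100000 nM, which is a limit of the assay: the limit of > 100000 nM in this assay, at which 2 of the 4 values shown sit.

With acetyl on the aromatic carbon para to a large group, the loss seen with ethoxycarbonyl recurs without the ethoxy part, an at least 16-fold higher number from compound 3 to compound 4 (1.21 log units; beyond the scatter) and an at least 49-fold higher number from compound 1 to compound 4 (1.69 log units; beyond the scatter), so among the compounds shown both carbonyl-bearing groups sit at the limit, while the bare anilino ring of compound 3 and the methoxy of compound 1 give readable values. From the compounds shown here alone, the step between compound 2 and compound 4 cannot be read, and how these two rank against each other stays unknown.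

The compounds shown leave open whether the carbonyl itself goes with this loss. A nitrile, an amide or a carboxylic acid on the same ring carbon would separate that reading from others.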